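Replacing the aryl ring of compound 1 with a butyl chain

The source may report more compounds than this note shows. Statements on the series, on what has been measured and on what is new or still open speak of the compounds shown alone.

Measured so far:
- compound 1, `COc1cccc(-n2cnc3cc(C(=O)N4CCCCC4)ccc32)c1`: 19 nM
- compound 2, `O=C(c1ccc2c(c1)ncn2-c1cccc(C(F)(F)F)c1)N1CCCCC1`: 48 nM
- compound 3, `CC(C)c1cccc(-n2cnc3cc(C(=O)N4CCCCC4)ccc32)c1`: 68 nM

All three numbers come from an assay on isolated protein for inhibition of 15-hydroxyprostaglandin dehydrogenase [NAD(+)] (Homo sapiens), read by fluorescence, with a stated time of 15 min; on this read-out lower numbers stand for stronger inhibition and higher numbers for weaker inhibition. Compound 1 stands lowest of the three, with compound 2 nearest and compound 3 furthest. The two steps away from compound 1 are a 2.5-fold higher number from compound 1 to compound 2 (0.40 log units; beyond the scatter) and a 3.6-fold higher number from compound 1 to compound 3 (0.55 log units; beyond the scatter); between compound 2 and compound 3 the step is a 1.4-fold higher number from compound 2 to compound 3 (0.15 log units; within the scatter).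

Compound 4, `CCCCn1cnc2cc(C(=O)N3CCCCC3)ccc21`, differs from compound 1 by butyl in place of 3-methoxyphenyl on an aromatic nitrogen. Among the compounds with values here, none of the measured steps makes this change: each of them swaps one group on the aryl ring for another, with the ring itself kept in place. Those steps show that even a change of one group on that ring moves the number beyond the scatter, and always upward from compound 1. Within the data shown here, removing the whole ring is a larger change than any of them, so a step larger than a 3.6-fold higher number from compound 1 to compound 3 (0.55 log units; beyond the scatter) is expected, in the direction of a higher number, with wide uncertainty because no measured pair shows this kind of change. Compound 4 is therefore estimated at 300 nM, with a range of 60 nM to 2000 nM, which corresponds to an expected step of a 16-fold higher number from compound 1 to compound 4 (1.20 log units; beyond the scatter).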

Compound 4, half-maximal inhibitory concentration: 68 nM
Compound 4: the middle estimate sits 4.4-fold (0.64 log units) above what was measured, within the range that was stated.
By their numbers in this assay, from the lowest: compound 1; then compounds 2, 3 and 4 (each within the scatter of the next).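

In this assay, the aromatic nitrogen of the shared core keeps a value in the same nanomolar range without any ring on it: butyl in place of 3-methoxyphenyl gives a 3.6-fold higher number from compound 1 to compound 4 (0.55 log units; beyond the scatter). Losing the entire 3-methoxyphenyl group, with its six-membered aromatic ring and its hydrogen-bond acceptor, thus moves the number by the same amount as the single exchange on that ring of isopropyl for methoxy, a 3.6-fold higher number from compound 1 to compound 3 (0.55 log units; beyond the scatter), so the aryl ring is not required at this position, although compound 1 remains lower than compound 4 by a margin beyond the scatter. No measurement at hand bears on why so large a change in the group costs so little.

The compounds shown leave open whether a saturated ring such as cyclohexyl on the same nitrogen would give a value nearer to that of compound 1 or to that of compound 4. They also leave open how a shorter chain such as ethyl, a longer chain such as hexyl, or a chain carrying a methoxy group would compare with butyl.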